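This account rests on a few compounds, and the source may have more. Where it says the series, first, only, none or still open, it means among the compounds named here.

Working notes on the series. Within the data shown here, compound 1 `Cc1cc(C(=O)Nc2cccc(F)c2)nn1Cc1cc(Cl)ccc1OCc1ccccc1` gives 2.8 in a physicochemical assay for lipophilicity, at pH 7.4 (on this read-out higher numbers stand for higher lipophilicity and lower numbers for lower lipophilicity), the only outright number in the set so far. Compound 2 `Cc1cc(NC(=O)OC(C)(C)C)nn1Cc1cc(Cl)ccc1OCc1ccccc1` is recorded in this assay only as a limit, > 3.7. The step of a number at least 0.90 log units higher from compound 1 to compound 2 (beyond the scatter) rests on the limit of > 3.7 in this assay, at which 1 of the 2 values shown sits, and therefore fixes a floor, not a size. Compound 3 `COC(=O)Nc1cc(C)n(Cc2cc(Cl)ccc2OCc2ccccc2)n1` is the next member and awaits measurement in this assay. Its difference from compound 1 is (methoxycarbonyl)amino in place of (3-fluorophenyl)carbamoyl on an aromatic carbon. Among the measured compounds shown here, the single measured step, from compound 1 to compound 2, removes the same departing group, (3-fluorophenyl)carbamoyl, and installs (tert-butoxycarbonyl)amino, a larger relative of the (methoxycarbonyl)amino that enters here; it is the only guide available, and with (methoxycarbonyl)amino carrying fewer heavy atoms than (tert-butoxycarbonyl)amino, the upward movement seen there is not expected to carry over. The step of a number 0.30 log units lower from compound 1 to compound 3 (within the scatter) is expected to be small, within the usual scatter, with a downward lean. Compound 3 is accordingly estimated to give about 2.5 in this assay, between 1.9 and 3.1.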

Compound 3, distribution coefficient: > 3.7
Compound 3: only a limit was reported (the forecaster's own chance of this, stated with the estimate: 5%); middle value at least 1.20 log units away from the limit.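

At this aromatic carbon, the rise from compound 1 does not depend on the larger (tert-butoxycarbonyl)amino, since (methoxycarbonyl)amino, with 5 heavy atoms, fewer than the departing (3-fluorophenyl)carbamoyl, gives a number at least 0.90 log units higher from compound 1 to compound 3 (beyond the scatter). In this assay, compound 3 is recorded only as a limit, > 3.7. The step between compound 2 and compound 3, methyl in place of tert-butyl on an oxygen next to a carbonyl group, cannot be read, and the rise to compound 3 fixes a floor, not a size: the limit of > 3.7 in this assay, at which 2 of the 3 values shown sit.

Left open is how far compound 2 and compound 3 actually lie from compound 1, and therefore whether the methyl and tert-butyl ends differ at all in this assay. Also open, as far as these compounds go, is whether a plain amine, a carboxylic acid or a simple acetamide on the same aromatic carbon, in place of (methoxycarbonyl)amino, would give an outright number in this assay and so allow this change to be sized.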